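From a 3-fluorophenyl amide to a pyridin-2-yl amide

The compounds below may be only part of what the source reports. "The series", "measured", "known", "first", "only" and "open" are said of these compounds alone.

- compound 1 `Cc1ccc(NC(=O)C2CCN(C/C=C/c3ccccc3)CC2)cc1` gives 29600 nM
- compound 2 `COc1ccc(NC(=O)C2CCN(C/C=C/c3ccccc3)CC2)cc1` gives 83800 nM
- compound 3 `O=C(Nc1cccc(F)c1)C1CCN(C/C=C/c2ccccc2)CC1` gives 43300 nM

These three values come from a functional assay on A549 cells (Homo sapiens) for inhibition, read by MTT assay, with a stated time of 72 h; a lower number here means a stronger inhibitor, a higher number a weaker inhibitor. Compound 3 has the second highest of the three numbers, but it cannot be separated from either of the others: the data show a 1.5-fold higher number from compound 1 to compound 3 (0.17 log units; within the scatter) and a 1.9-fold lower number from compound 2 to compound 3 (0.29 log units; within the scatter). Among the measured compounds shown here, the only step that exceeds the scatter is modest, namely a 2.8-fold higher number from compound 1 to compound 2 (0.45 log units; beyond the scatter).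

The next structure is compound 4 `O=C(Nc1ccccn1)C1CCN(C/C=C/c2ccccc2)CC1`, and the change is pyridin-2-yl in place of 3-fluorophenyl on an amide-type nitrogen. This places pyridin-2-yl in place of 3-fluorophenyl on an amide-type nitrogen. For the measured compounds named here, the two steps that exchange the group at this place, a 1.5-fold higher number from compound 1 to compound 3 (0.17 log units; within the scatter) and a 1.9-fold lower number from compound 2 to compound 3 (0.29 log units; within the scatter), are the closest guides, although no measured compound carries a ring with a hetero atom there. Going by these compounds, no shift beyond the scatter is therefore expected, and the direction remains open. The expected change is a 1.2-fold higher number from compound 3 to compound 4 (0.06 log units; within the scatter). For compound 4 the estimate is 50000 nM, with an expected range of 20000 nM to 120000 nM.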

Compound 4, half-maximal inhibitory concentration: 89300 nM
The estimate for compound 4 lay 1.8-fold (0.25 log units) below the measured number; measured number inside the range.
By their numbers in this assay, from the lowest: compounds 1, 3, 2 and 4 (each within the scatter of the next, the first and the last beyond it).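

In this assay, pyridin-2-yl on the amide-type nitrogen separates from 3-fluorophenyl, with a 2.1-fold higher number from compound 3 to compound 4 (0.31 log units; beyond the scatter) as a modest step beyond the scatter, whereas neither step into compound 3 left the scatter. The contrast with the 4-methylphenyl amide is also modest, with a 3.0-fold higher number from compound 1 to compound 4 (0.48 log units; beyond the scatter) on this exchange, while a 1.1-fold higher number from compound 2 to compound 4 (0.03 log units; within the scatter) leaves pyridin-2-yl and 4-methoxyphenyl inseparable, so a ring with a hetero atom at this place gives no separation from every carbon-only ring. No available measurement bears on the reason for these differences. The compounds shown leave open whether a pyrimidine ring at this place would fall with compound 4 or with compound 3. They also leave open how an amine or a carboxylic acid on this ring would read.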